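A Methyl Step Repeated on a Second Core

A few compounds are considered here, and "the series" means these few. Any claim that something is new, unique, unknown or untested is made for them only; others in the source may bear on it.

Compound 1 `CC[C@H](CCn1cncn1)c1ccccc1`: 99.8 ug/mL
Compound 2 `CC[C@H](CCn1cncn1)c1ccc(C)cc1`: 85.2 ug/mL
Compound 3 `c1ccc([C@@H](CCn2cncn2)C2CCCCC2)cc1`: 9.2 ug/mL

Of the compounds shown here, three have been tested in an ADME assay on RD cells (Homo sapiens) for cytotoxicity, read by MTT assay, with a stated time of 3 days; on this read-out lower numbers stand for higher toxicity in this test and higher numbers for lower toxicity in this test. Compound 1 gives 99.8 ug/mL and compound 2 gives 85.2 ug/mL in this assay; the two differ by methyl in place of hydrogen on an aromatic carbon, and the step of a 1.2-fold lower number from compound 1 to compound 2 (0.07 log units; within the scatter) is within the scatter. Compound 3 gives 9.2 ug/mL in this assay and differs from compound 1 by cyclohexyl in place of ethyl on a saturated chain carbon bound to an aromatic carbon and a saturated chain carbon; this step, an 11-fold lower number from compound 1 to compound 3 (1.04 log units; beyond the scatter), is large and beyond the scatter, so compound 3 has the lowest number of the three.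

Compound 4 `Cc1ccc([C@@H](CCn2cncn2)C2CCCCC2)cc1` has not yet been measured. It differs from compound 3 by methyl in place of hydrogen on an aromatic carbon, the same change that was made from compound 1 to compound 2, at a place described in the same words. Because the step of a 1.2-fold lower number from compound 1 to compound 2 (0.07 log units; within the scatter) was within the scatter, the step of a 1.2-fold lower number from compound 3 to compound 4 (0.09 log units; within the scatter) is expected to be small as well, and compound 4 is estimated to give 7.5 ug/mL in this assay, with a likely range from 3.5 ug/mL to 16 ug/mL.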

Compound 4, half-maximal cytotoxic concentration: 57.9 ug/mL
For compound 4 the middle estimate is 7.7-fold (0.89 log units) below the measured one, outside the stated range (above it).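

The methyl step did not carry from one core to the other in this assay: on the cyclohexyl core it gives a 6.3-fold higher number from compound 3 to compound 4 (0.80 log units; beyond the scatter), and it does not match the step on the core of compound 1: the same change on two cores in this assay, a 1.2-fold lower number (0.07 log units; within the scatter) from compound 1 to compound 2 and a 6.3-fold higher number (0.80 log units; beyond the scatter) from compound 3 to compound 4, 7.4-fold (0.87 log units) apart, beyond the scatter of two such steps. The change from ethyl to cyclohexyl likewise depends on the core that receives it, giving a 1.5-fold lower number from compound 2 to compound 4 (0.17 log units; within the scatter) when the methyl is already present: the same change on two cores in this assay, an 11-fold lower number (1.04 log units; beyond the scatter) from compound 1 to compound 3 and a 1.5-fold lower number (0.17 log units; within the scatter) from compound 2 to compound 4, 7.4-fold (0.87 log units) apart, beyond the scatter of two such steps. Both comparisons rest on the same four compounds and so record a single departure from simple addition of the two changes; they show that a step read on one core could not be carried to the other here, but they do not show why, and they give no rule for any further core.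

As far as these compounds go, it remains open whether a methoxy group or a chlorine atom in the same place would follow the methyl on these two cores. Also open, from the compounds shown here alone, is whether a longer chain in place of cyclohexyl would give a step like that seen with or without the methyl.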